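The source may hold more compounds than are shown below. What is called first, only, known or untested is meant among the compounds shown, and "the series" means these compounds.

Series notes, with values from an assay on isolated protein for displacement of a labelled ligand from Apoptosis regulator Bcl-2 (Homo sapiens), with a stated time of 15 min; on this read-out higher numbers stand for weaker inhibition and lower numbers for stronger inhibition:

compound 1 — `CCN(CC)CCCNc1ccc(S(=O)(=O)NC(=O)c2ccc(N3CCN(CC4=C(c5ccc(C(F)(F)F)cc5)CC(C)(C)CC4)CC3)cc2Oc2cnc3[nH]ccc3c2)cc1[N+](=O)[O-]` — compound 1 gives 0.3 nM
compound 2 — `CC1(C)CCC(CN2CCN(c3ccc(C(=O)NS(=O)(=O)c4ccc(OC5CCOCC5)c([N+](=O)[O-])c4)c(Oc4cnc5[nH]ccc5c4)c3)CC2)=C(c2ccc(C(F)(F)F)cc2)C1` — compound 2 gives 8.4 nM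
compound 3 — `CC1(C)CCC(CN2CCN(c3ccc(C(=O)NS(=O)(=O)c4ccc(OCC5CCCOC5)c([N+](=O)[O-])c4)c(Oc4cnc5[nH]ccc5c4)c3)CC2)=C(c2ccc(C(F)(F)F)cc2)C1` — compound 3 gives 3 nM

Compound 3 sits second highest of the three numbers. Its nearest neighbour is compound 2, where the change is a 2.8-fold lower number from compound 2 to compound 3 (0.45 log units; beyond the scatter); the furthest is compound 1, where a 10-fold higher number from compound 1 to compound 3 (1.00 log units; beyond the scatter).

The next compound is compound 4, `CC1(C)CCC(CN2CCN(c3ccc(C(=O)NS(=O)(=O)c4ccc(OCC5CCSCC5)c([N+](=O)[O-])c4)c(Oc4cnc5[nH]ccc5c4)c3)CC2)=C(c2ccc(C(F)(F)F)cc2)C1`. Relative to compound 3 the change is thian-4-yl in place of oxan-3-yl on a saturated chain carbon bound to an oxygen on an aromatic ring.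

Of the measured steps, only a 2.8-fold lower number from compound 2 to compound 3 (0.45 log units; beyond the scatter) concerns a change on the ether side chain, and that step was modest. The other two, a 28-fold higher number from compound 1 to compound 2 (1.45 log units; beyond the scatter) and a 10-fold higher number from compound 1 to compound 3 (1.00 log units; beyond the scatter), replace the whole amine-bearing chain with an ether and do not speak to a swap of one six-membered saturated ring for another. Among the measured compounds shown here, no measured pair exchanges an oxygen-containing ring for a sulfur-containing one, so the direction is open; a step of at most modest size in this assay is expected, most likely within the scatter.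

Compound 4 is therefore estimated at 3 nM, with a range of 1 nM to 9 nM, which means an expected step of no change at the digits printed from compound 3 to compound 4 (within the scatter).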

Compound 4, half-maximal inhibitory concentration: 1.65 nM
The estimate for compound 4 lay 1.8-fold (0.26 log units) above the measured number; measured number inside the range.
By their numbers in this assay, from the lowest: compound 1; then compounds 4 and 3 (each within the scatter of the next); then compound 2.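

In this assay, (thian-4-yl)methyl on the oxygen on an aromatic ring gives a 1.8-fold lower number from compound 3 to compound 4 (0.26 log units; within the scatter), so a sulfur-containing ring is tolerated on this ether side chain and compound 4 cannot be separated from compound 3. The same group gives a 5.1-fold lower number from compound 2 to compound 4 (0.71 log units; beyond the scatter), which places compound 4 with compound 3 and apart from the oxan-4-yl ether compound 2. Even so, a 5.5-fold higher number from compound 1 to compound 4 (0.74 log units; beyond the scatter) shows that this ether does not reach the number of compound 1, which carries the (3-(diethylamino)propyl)amino chain.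

The step from compound 3 to compound 4 changes both the ring hetero atom and the ring attachment, so a (oxan-4-yl)methyl or (thian-3-yl)methyl group would be needed to separate the two, while a (piperidin-4-yl)methyl group would test a ring amine at this place. No evidence is available to explain any of these differences.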